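This account rests on a few compounds, and the source may have more. Where it says the series, first, only, none or still open, it means among the compounds named here.

Working notes on the series.

Compound 1 `COc1cc(C=C(C(=O)/C=C/c2cccc(OC)c2OC)C(=O)/C=C/c2cccc(OC)c2OC)cc(Br)c1O` and compound 2 `COc1cc(C=C(C(=O)/C=C/c2cccc(OC)c2OC)C(=O)/C=C/c2cccc(OC)c2OC)cc(OC)c1O` share one core; compound 3 `COc1ccc(/C=C/C(=O)C(=Cc2cc(Br)c(O)c(OC)c2)C(=O)/C=C/c2ccc(OC)cc2OC)c(OC)c1` and compound 4 `COc1ccc(/C=C/C(=O)C(=Cc2cc(OC)c(O)c(OC)c2)C(=O)/C=C/c2ccc(OC)cc2OC)c(OC)c1` share another. In a functional assay on CNE-2 cells (Homo sapiens) for antiproliferative activity, read by sulforhodamine B assay, with a stated time of 48 h (on this read-out lower numbers stand for stronger inhibition and higher numbers for weaker inhibition), compound 1 gives 220 nM, and compound 2 gives 300 nM. Among the compounds with values here, the one change between them, (methoxy in place of bromo on an aromatic carbon), gave a 1.4-fold higher number from compound 1 to compound 2 (0.13 log units; within the scatter). In this assay compound 3 gives 1780 nM, the highest number of the three measured; the difference between the core of compound 3 and the core of compound 1 is not broken down here, the two having the same atoms joined differently.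

Compound 4 carries the same change against compound 3, (methoxy in place of bromo on an aromatic carbon), at a place described in the same words as for compound 1 and compound 2. It is not yet measured in this assay. It is expected that a 1.3-fold higher number from compound 3 to compound 4 (0.11 log units; within the scatter), beside a 1.4-fold higher number from compound 1 to compound 2 (0.13 log units; within the scatter), because in this assay compound 1 gives 220 nM and compound 2 gives 300 nM, a step within the scatter. Compound 4 is therefore estimated at 2300 nM, with a range from 1000 nM to 5500 nM.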

Compound 4, half-maximal inhibitory concentration: 850 nM
Estimate against measurement, compound 4: 2.7-fold (0.43 log units) above, outside the stated range (below it).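

In this assay the change from bromo to methoxy does not carry over unchanged from one core to the other: the same change on two cores in this assay, a 1.4-fold higher number (0.13 log units; within the scatter) from compound 1 to compound 2 and a 2.1-fold lower number (0.32 log units; beyond the scatter) from compound 3 to compound 4, 2.9-fold (0.46 log units) apart, beyond the scatter of two such steps. The change gives a 2.1-fold lower number from compound 3 to compound 4 (0.32 log units; beyond the scatter) on one core and a 1.4-fold higher number from compound 1 to compound 2 (0.13 log units; within the scatter) on the other, so a step read on one of these cores cannot simply be transferred to the other in this series. This rests on a single pair per core and shows neither what in the cores separates the two steps nor whether other changes at this place would depend on the core in the same way.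

The compounds shown leave open how other groups at this place, such as chloro, an amine or a carboxylic acid, would behave on each core. Also open, from the compounds shown here alone, is which part of the difference between the core of compound 1 and the core of compound 3 sets the size of the step.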